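Chloro in Place of Fluoro: Expected Dose for Compound 4

The source may report more compounds than this note shows. Statements on the series, on what has been measured and on what is new or still open speak of the compounds shown alone.

Measured so far in a functional assay on the whole organism (strain Albino) with Mus musculus as the target, with a stated time of 4 h; on this read-out higher numbers stand for an effect only at larger amounts of compound and lower numbers for an effect already at smaller amounts:
compound 1 `COc1ccc(-c2cc(-c3ccc(F)cc3)nc(NC(=O)N/N=C\c3ccccc3Cl)n2)c(OC)c1`: 300 mg/kg
compound 2 `C/C(=N/NC(=O)Nc1nc(-c2ccc(F)cc2)cc(-c2ccc([N+](=O)[O-])cc2)n1)c1ccc(C)cc1`: 300 mg/kg
compound 3 `COc1ccc(-c2cc(-c3ccc(Cl)cc3)nc(NC(=O)N/N=C\c3ccccc3Cl)n2)c(OC)c1`: 300 mg/kg

Compound 3 differs from compound 1 by chloro in place of fluoro on an aromatic carbon, and the step of no change at the digits printed from compound 1 to compound 3 (within the scatter) in this assay. Compound 2 stands level with compound 1 and compound 3 at the digits printed in this assay; the difference between the core of compound 2 and the core of compound 1 is not broken down here. Compound 4 `C/C(=N/NC(=O)Nc1nc(-c2ccc(Cl)cc2)cc(-c2ccc([N+](=O)[O-])cc2)n1)c1ccc(C)cc1` is not yet measured; it differs from compound 2 by chloro in place of fluoro on an aromatic carbon, the same change as from compound 1 to compound 3, at a place described in the same words. Because no change at the digits printed from compound 1 to compound 3 (within the scatter), the step of no change at the digits printed from compound 2 to compound 4 (within the scatter) is expected to be of the same size. Compound 4 is therefore estimated at 300 mg/kg in this assay, with a range from 150 mg/kg to 600 mg/kg.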

Compound 4, dose for half-maximal effect: 300 mg/kg
Compound 4: the middle estimate sits on the measured number at the digits printed; the measured number falls inside the stated range.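

In this assay, the exchange of 4-fluorophenyl for 4-chlorophenyl reads no change at the digits printed from compound 2 to compound 4 (within the scatter). Set beside the earlier step, the change carries over from one core to the other: the same change on two cores in this assay, no change at the digits printed (within the scatter) from compound 1 to compound 3 and no change at the digits printed (within the scatter) from compound 2 to compound 4, 1.0-fold (0.00 log units) apart, within the scatter of two such steps. Among these compounds, this shows only that the change left the dose unmoved on these two cores; it shows nothing about whether a step of real size would carry over, and two cores do not stand for the whole series.

As far as these compounds go, whether an amine or a carboxylic acid at this place would shift the dose in this assay stays open. From the compounds shown here alone, with all four compounds level at the digits printed, it also stays open which parts of the structure this dose responds to at all.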